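The source may report more compounds than this note shows. Statements on the series, on what has been measured and on what is new or still open speak of the compounds shown alone.

Working notes on the series in an ADME assay on MDCK cells (Canis lupus familiaris) for cytotoxicity, read by microscopy, with a stated time of 48 h; a lower number here means that less compound is tolerated, a higher number that more compound is tolerated. Compound 1 `Cc1ccsc1CN[C@@H]1C[C@H]2C[C@@H]([C@H]1C)C2(C)C` gives 10000 nM in this assay. Compound 2 `C[C@H]1[C@H](NCc2ccsc2)C[C@H]2C[C@@H]1C2(C)C` gives 50000 nM in this assay. Compound 3 `C[C@H]1[C@H](NCc2ccoc2)C[C@H]2C[C@@H]1C2(C)C` reaches only a limit of this assay, > 100000 nM, so no number is known for it. Among the values shown, compound 3 therefore stands at the top end, at the limit of > 100000 nM in this assay, at which 1 of the 3 values shown sits. The measured steps are a 5.0-fold higher number from compound 1 to compound 2 (0.70 log units; beyond the scatter), an at least 10-fold higher number from compound 1 to compound 3 (1.00 log units; beyond the scatter) and an at least 2.0-fold higher number from compound 2 to compound 3 (0.30 log units; that floor lies within the scatter).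

Compound 4 `C[C@H]1[C@H](NCc2ccco2)C[C@H]2C[C@@H]1C2(C)C` is the next variant; its change from compound 3 is furan-2-yl in place of furan-3-yl on a saturated chain carbon bound to an amine nitrogen. Within the data shown here, no measured step swaps one furan isomer for the other. The step that comes closest is a 5.0-fold higher number from compound 1 to compound 2 (0.70 log units; beyond the scatter), where a 3-methylthiophen-2-yl gives way to a thiophen-3-yl and the number rose, but that step removes a methyl at the same time, so it cannot be read as a clean isomer swap. The step of an at least 2.0-fold higher number from compound 2 to compound 3 (0.30 log units; that floor lies within the scatter) only shows that furan-3-yl sits at or above thiophen-3-yl.

On this basis a step toward a lower number, of modest size at most, is expected from compound 3 to compound 4, namely an at least 1.2-fold lower number from compound 3 to compound 4 (0.09 log units; that floor lies within the scatter), with a real chance that compound 4 again returns only a limit. The estimate for compound 4 is 80000 nM, expected to lie between 30000 nM and 200000 nM.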

Compound 4, minimum cytotoxic concentration: 50000 nM
Beside the measured number, compound 4's estimate is 1.6-fold (0.20 log units) above it; the range from low to high includes it.
By their numbers in this assay, from the lowest: compound 1; then compounds 2 and 4 (each within the scatter of the next). At a limit, above all of these: compound 3.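

In this assay, this is the first direct swap of one furan isomer for the other on a saturated chain carbon bound to an amine nitrogen, and furan-2-yl in place of furan-3-yl gives only a floor (an at least 2.0-fold lower number from compound 3 to compound 4 (0.30 log units; that floor lies within the scatter)), so the two isomers are not shown to differ. Furan-2-yl and thiophen-3-yl cannot be told apart at this place (no change at the digits printed from compound 2 to compound 4 (within the scatter)), while furan-2-yl stands clear of the 3-methylthiophen-2-yl group (a 5.0-fold higher number from compound 1 to compound 4 (0.70 log units; beyond the scatter)), which leaves compound 1 as the only compound separated from each of the others by more than the scatter. From the compounds shown here alone, compound 3 remains a limit and not a number, so the full size of the isomer step stays unknown: the limit of > 100000 nM in this assay, at which 1 of the 4 values shown sits.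

The compounds shown leave open whether the separation of compound 1 goes with the methyl or with the point of attachment to the thiophene, as 3-methylthiophen-2-yl differs from thiophen-3-yl in both at once, and an unsubstituted thiophen-2-yl would divide the two. Going by these compounds, how a phenyl or a pyridin-3-yl group on the same saturated chain carbon would read in this assay is also open.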